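Methyl for Hydrogen on an Amine Nitrogen, Made Twice

The source may report more compounds than this note shows. Statements on the series, on what has been measured and on what is new or still open speak of the compounds shown alone.

In a functional assay on A2780 cells (Homo sapiens) for antiproliferative activity, read by MTT assay, with a stated time of 48 h (a higher number here means a weaker inhibitor, a lower number a stronger inhibitor), compound 1 `COc1ccc(C(=O)c2ccc(OC)c3c2OC(C)(C)C=C3)c(NC(=O)CN)c1` gives 380 nM. Compound 3 `CNCC(=O)Nc1cc(OC)ccc1C(=O)c1ccc(OC)c2c1OC(C)(C)C=C2` differs from compound 1 in a single place, (methyl in place of hydrogen on an amine nitrogen); in this assay compound 3 gives 620 nM, and the step of a 1.6-fold higher number from compound 1 to compound 3 (0.21 log units; within the scatter). Compound 2 `COc1ccc(C(=O)c2ccc3c(c2)C=CC(C)(C)O3)c(NC(=O)CN)c1` is built on a different core; the difference between the two cores is not broken down here. In this assay compound 2 gives 590 nM, a number that lies within the scatter of compound 3 and within the scatter of compound 1, so none of the three measured compounds can be placed above or below another.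

Compound 4 `CNCC(=O)Nc1cc(OC)ccc1C(=O)c1ccc2c(c1)C=CC(C)(C)O2` has not yet been measured. It stands to compound 2 as compound 3 stands to compound 1: methyl in place of hydrogen on an amine nitrogen. The place is described in the same words for both pairs, an amine nitrogen whose other neighbour is a saturated chain carbon, so this is the same change made twice among the compounds shown, once on each core.

With a single measured example of the change, the expectation for compound 4 rests on that one step alone. Because a 1.6-fold higher number from compound 1 to compound 3 (0.21 log units; within the scatter) lay within the scatter, the expected step is a 1.5-fold higher number from compound 2 to compound 4 (0.18 log units; within the scatter). In this assay compound 4 is estimated at 900 nM, with a range from 450 nM to 1800 nM.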

Compound 4, half-maximal inhibitory concentration: 850 nM
Estimate against measurement, compound 4: 1.1-fold (0.02 log units) above; the range from low to high includes it.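

With a 1.4-fold higher number from compound 2 to compound 4 (0.16 log units; within the scatter) in this assay, methyl in place of hydrogen on an amine nitrogen has now been read on both cores, and the two steps do not differ: the same change on two cores in this assay, a 1.6-fold higher number (0.21 log units; within the scatter) from compound 1 to compound 3 and a 1.4-fold higher number (0.16 log units; within the scatter) from compound 2 to compound 4, 1.1-fold (0.05 log units) apart, within the scatter of two such steps.

As far as these two pairs go, the change carries from the core of compound 1 to the core of compound 2 with no difference that can be told from the scatter. This does not show that the methyl alters the number at all: each step on its own lies within the scatter, so what agrees here is two small steps, not a clear effect that repeats, and two cores say nothing about a third.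

The compounds shown leave open how a larger group on this nitrogen would read, such as an ethyl, a second methyl giving the dimethylamino group, or an acetyl, and whether any of these would give a step beyond the scatter. They also leave open how a longer chain in place of the aminomethyl, or a hydroxyl in place of the amine, would read on either core.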